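Removing the Fluorine from Compound 2: What to Expect

A few compounds are considered here, and "the series" means these few. Any claim that something is new, unique, unknown or untested is made for them only; others in the source may bear on it.

Compound 2 `Nc1cccc(/C=C2\SC(=O)N(Cc3cccc(F)c3)C2=O)c1` and compound 1 `Nc1cccc(/C=C2\SC(=O)N(Cc3ccc(F)cc3)C2=O)c1` share one core and differ only in where a single fluorine sits on the fluorophenyl ring. In a functional assay on HeLa cells (Homo sapiens) for cytotoxicity, read by cell counting, with a stated time of 4 days (on this read-out lower numbers stand for stronger inhibition and higher numbers for weaker inhibition), compound 1 gives 86000 nM. For compound 2 the same this assay gives only a limit, > 250000 nM, so its true number is not known. Because of the limit of > 250000 nM in this assay, at which 1 of the 2 values shown sits, the step of an at least 2.9-fold higher number from compound 1 to compound 2 (0.46 log units; beyond the scatter) can only be given as a least size. Compound 3 `Nc1cccc(/C=C2\SC(=O)N(Cc3ccccc3)C2=O)c1` has not yet been measured. It arises from compound 2 by hydrogen in place of fluoro on an aromatic carbon, so the ring carries no fluorine at all. No measured step removes a fluorine; the one step shown moves it, and that step is beyond the scatter. Compound 3 lies between the two measured cases in substitution, and no shown step tells whether removing the fluorine matters more than moving it. The step of an at least 1.2-fold lower number from compound 2 to compound 3 (0.09 log units; that floor lies within the scatter) is my estimate, a middle guess starting from a limit. Compound 3 is expected at 200000 nM, between 70000 nM and 600000 nM, in this assay.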

Compound 3, half-maximal inhibitory concentration: > 250000 nM
Compound 3: no number, only a limit; the forecaster's own chance of this, stated with the estimate: 45%; at least 1.2-fold (0.09 log units) between middle value and limit.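

The new result turns a single comparison into a small series: of the three ring patterns shown, only the 4-fluorophenyl group of compound 1 gives a real number in this assay. Taking that fluorine away altogether gives an at least 2.9-fold higher number from compound 1 to compound 3 (0.46 log units; beyond the scatter), so the plain phenyl ring, like the 3-fluorophenyl ring, fails to match compound 1, and both a moved fluorine and an absent one leave the compound with a weaker reading. The step from compound 2 to compound 3 cannot be read, and nothing can be said about how these two compare, because each is recorded only as a limit and not as a number: the limit of > 250000 nM in this assay, at which 2 of the 3 values shown sit.

From the compounds shown here alone, what stays open is how far the true values of compound 2 and compound 3 lie beyond that limit, and so whether the fluorine in compound 2 makes any difference at all. Going by these compounds, it is also open whether a chlorine, a methoxy group or an amine in place of the fluorine of compound 1 would give a lower number than compound 1 or would lose the reading as well.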